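From a Ring to a Dimethylamino Group on the Core

The compounds below may be only part of what the source reports. "The series", "measured", "known", "first", "only" and "open" are said of these compounds alone.

Measured so far:
compound 1, `Cc1cc(C)cc(Cn2c(=O)cc(NC3CCCCC3)n(Cc3ccccc3)c2=O)c1` — 74000 nM
compound 2, `Cc1cc(C)cc(Cn2c(=O)cc(N3CCCC3)n(Cc3ccccc3)c2=O)c1` — 31000 nM
compound 3, `Cc1cc(C)cc(Cn2c(=O)cc(N)n(Cc3ccccn3)c2=O)c1` — > 100000 nM

In an ADME assay on MT4 cells (Homo sapiens) for cytotoxicity, read by MTT assay, with a stated time of 4 days (a lower number here means that less compound is tolerated, a higher number that more compound is tolerated), compound 2 gives 31000 nM and stands at the lowest of the two numbers shown. Its nearest neighbour is compound 1, which gives 74000 nM in this assay. The value of compound 3, > 100000 nM, is a limit of this assay and not a number. Within the data shown here, the one measured step that can be compared is a 2.4-fold lower number from compound 1 to compound 2 (0.38 log units; beyond the scatter), a modest change that goes beyond the scatter.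

Compound 4, `Cc1cc(C)cc(Cn2c(=O)cc(N(C)C)n(Cc3ccccc3)c2=O)c1`, differs from compound 2 in one place: dimethylamino in place of pyrrolidin-1-yl on an aromatic carbon. This step also reduces the amine substituent on the core, as the step from compound 1 to compound 2 did, and that step lowered the number; the change here is smaller in size than that one. A step of a 1.2-fold lower number from compound 2 to compound 4 (0.09 log units; within the scatter) is therefore expected, small and most likely within the scatter or slightly downward. Compound 4 is expected to give about 25000 nM, with a range from 10000 nM to 70000 nM.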

Compound 4, half-maximal cytotoxic concentration: 48000 nM
Compound 4: the middle estimate sits 1.9-fold (0.28 log units) below what was measured; the measured number falls inside the stated range.
By their numbers in this assay, from the lowest: compounds 2, 4 and 1 (each within the scatter of the next, the first and the last beyond it). At a limit, above all of these: compound 3.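

In this assay, the exchange of the pyrrolidin-1-yl ring for open dimethylamino, with fewer heavy atoms, gives a 1.5-fold higher number from compound 2 to compound 4 (0.19 log units; within the scatter), so at this position on the shared core, opening and shortening the substituent leaves no readable change. The exchange of cyclohexylamino for dimethylamino gives a 1.5-fold lower number from compound 1 to compound 4 (0.19 log units; within the scatter), so compound 4 cannot be told apart from either neighbour, although the earlier step of a 2.4-fold lower number from compound 1 to compound 2 (0.38 log units; beyond the scatter) separated those two neighbours. The three numbers therefore do not support a steady trend with the size of the amine substituent, and only the gap between the cyclohexylamino and pyrrolidin-1-yl compounds lies beyond the scatter.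

Among these compounds, compound 3 gives a limit and not a number, so no step to it can be read: the limit of > 100000 nM in this assay, at which 1 of the 4 values shown sits. What remains open is how the same place on the core would respond to a morpholine ring, a diethylamino group, a longer alkyl chain on the nitrogen or a carboxylic acid on the amine substituent, with the benzyl and 3,5-dimethylbenzyl groups kept as they are.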